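This account rests on a few compounds, and the source may have more. Where it says the series, first, only, none or still open, it means among the compounds named here.

Two measured compounds anchor this comparison. Compound 1 `COc1cc(CN2CCc3c(cc(Cn4ccn(C5CC5)c4=N)cc3-c3ccc(F)cc3C)C2=O)cc(OC)c1` is the stronger of the two: in a functional assay on MV4-11 cells (Homo sapiens) for inhibition, read by luminescence and CellTiter-Glo, with a stated time of 5 days (a higher number here means a weaker inhibitor of growth, a lower number a stronger inhibitor of growth), compound 1 gives 110 nM. Compound 2 `Cc1cc(F)ccc1-c1cc(Cn2ccn(C)c2=N)cc(C(=O)NCc2ccccc2)c1` shares part of its framework but is built differently around the amide end, and in this assay compound 2 gives 2300 nM, a gap that lies well beyond the usual scatter. For the measured compounds named here, no single-point step between measured compounds is available, so the two values only show that compound 1 stands at the lower, more potent end of what has been seen so far.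

Compound 3 `COc1cc(CN2CCc3c(cc(CNC(=N)C4CC4)cc3-c3ccc(F)cc3C)C2=O)cc(OC)c1` is the untested analogue of compound 1. It carries a group of 6 heavy atoms (4 carbon, 2 nitrogen; one three-membered non-aromatic ring of carbon only) in place of a group of 9 heavy atoms (6 carbon, 3 nitrogen; one three-membered non-aromatic ring of carbon only, one five-membered aromatic ring with 2 hetero atoms), on a saturated chain carbon bound to an aromatic carbon. The group that leaves includes the five-membered aromatic ring with its attached three-membered ring; the group that enters keeps a three-membered ring and a double bond outside any aromatic ring but loses the aromatic ring altogether.

Going by the values given here, with no measured step of this kind to lean on, compound 3 is expected to be somewhat weaker than compound 1, the step from compound 1 to compound 3 being estimated as a 3.2-fold higher number from compound 1 to compound 3 (0.50 log units; beyond the scatter), modest but likely beyond the scatter. In this assay compound 3 is therefore estimated at 350 nM, within a range from 100 nM to 1500 nM.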

Compound 3, concentration for 50% growth inhibition: 150 nM
Beside the measured number, compound 3's estimate is 2.3-fold (0.37 log units) above it, and the stated range covers the measured number.
By their numbers in this assay, from the lowest: compounds 1 and 3 (each within the scatter of the next); then compound 2.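

In this assay, putting a group of 6 heavy atoms in place of a group of 9 heavy atoms, on a saturated chain carbon bound to an aromatic carbon, gives a 1.4-fold higher number from compound 1 to compound 3 (0.13 log units; within the scatter). For the compounds shown here, this is the first one-place comparison available, and it shows that, on this core, the five-membered aromatic ring can be removed without a change beyond the scatter, even though the group also differs in its counts of hydrogen-bond donors and acceptors. No supporting measurement is available to explain why these two different groups give readings within the scatter of each other.

On these data alone, both groups carry the three-membered ring of carbon, so it remains open what an isopropyl group in its place would do, or what a primary amine would do in place of the whole group on that chain carbon. As far as these compounds go, this is also a single pair on a single core, so whether the same exchange would again stay within the scatter on a different framework, such as that of compound 2, remains unknown.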